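The source may hold more compounds than are shown below. What is called first, only, known or untested is meant among the compounds shown, and "the series" means these compounds.

Compound 1 `CCN(CC)CC(=O)OC1CC2(N(C)C)CC(c3ccccc3)C1C(c1ccccc1)C2` gives 30100 nM
Compound 2 `CCN(CC)CC(=O)OC1CC2(N3CCCCC3)CC(c3ccccc3)C1C(c1ccccc1)C2` gives 23900 nM

For the measured compounds named here, in an ADME assay on L6 cells (Rattus norvegicus) for cytotoxicity, read by resazurin assay, with a stated time of 72 h (a lower number here means a stronger inhibitor, a higher number a weaker inhibitor), compound 2 stands on a par with compound 1 (the only measured step is a 1.3-fold lower number from compound 1 to compound 2 (0.10 log units; within the scatter)), and that step concerns a different substituent. Compound 3 `CN1CCN(CCC(=O)NC2CC3(N4CCCCC4)CC(c4ccccc4)C2C(c2ccccc2)C3)CC1` carries ((2-(4-methylpiperazin-1-yl)ethyl)carbonyl)amino in place of (((diethylamino)methyl)carbonyl)oxy on a saturated ring carbon. Going by the values given here, no measured step covers this exchange, so the one available step gives only weak guidance. No step beyond the scatter is expected in this assay, and no direction is favoured (estimated step: a 1.3-fold higher number from compound 2 to compound 3 (0.10 log units; within the scatter)). For compound 3 the estimated value is 30000 nM (expected range 10000 nM to 90000 nM).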

Compound 3, half-maximal inhibitory concentration: 61100 nM
Estimate against measurement, compound 3: 2.0-fold (0.31 log units) below; the range from low to high includes it.
By their numbers in this assay, from the lowest: compounds 2 and 1 (each within the scatter of the next); then compound 3.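

In this assay, for the compounds shown here, the saturated ring carbon bearing the (((diethylamino)methyl)carbonyl)oxy group gives the first step beyond the scatter (a 2.6-fold higher number from compound 2 to compound 3 (0.41 log units; beyond the scatter)), when ((2-(4-methylpiperazin-1-yl)ethyl)carbonyl)amino enters there. This modest step contrasts with the piperidin-1-yl exchange, which stayed within the scatter. The data at hand offer no explanation for the step.

Open, from the compounds shown here alone, is which part of the exchange carries the step: the amino link in place of oxy, or the 4-methylpiperazin-1-yl end in place of diethylamino. A diethylamino end on the amino link would separate the two.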